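A few compounds are considered here, and "the series" means these few. Any claim that something is new, unique, unknown or untested is made for them only; others in the source may bear on it.

Series notes. In a functional assay for inhibition, with Homo sapiens as the target (on this read-out higher numbers stand for weaker inhibition and lower numbers for stronger inhibition), compound 2 `CCCc1nnc(O)n2c(CCC)nc(C)c12` gives 16000 nM, the only number shown. Compound 1 `CCCCc1nnc(O)n2c(CCC)nc(C)c12` sits at > 48000 nM, a limit of the assay. Compound 3 `CCCc1nnc(SC)n2c(CCC)nc(C)c12` likewise sits at > 48000 nM, a limit. Two of the three values therefore sit at the limit of > 48000 nM in this assay, at which 2 of the 3 values shown sit. The step from compound 1 to compound 2 is an at least 3.0-fold lower number from compound 1 to compound 2 (0.47 log units; beyond the scatter), and the step from compound 2 to compound 3 is an at least 3.0-fold higher number from compound 2 to compound 3 (0.47 log units; beyond the scatter). Compound 4 `CCCc1nc(C)c2c(C3CC3)nnc(O)n12` differs from compound 2 by cyclopropyl in place of propyl on an aromatic carbon. Neither measured step concerns a cyclopropyl; the first shortens the same chain, the second alters the hydroxy group. Expected is no change at the digits printed from compound 2 to compound 4 (within the scatter), a step not beyond the scatter. The estimate for compound 4 is 16000 nM, with a range from 6000 nM to 48000 nM.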

Compound 4, half-maximal inhibitory concentration: > 48000 nM
Compound 4: no number, only a limit; the forecaster's own chance of this, stated with the estimate: 30%; at least 3.0-fold (0.47 log units) between middle value and limit.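

Replacing the chain with a ring of the same heavy-atom count on this aromatic carbon, para to a hydroxy group, is not a neutral change in this assay: the result is an at least 3.0-fold higher number from compound 2 to compound 4 (0.47 log units; beyond the scatter). Of the groups on this carbon, only propyl now has a number, and the step from compound 1 to compound 4 cannot be read, as both ends are limits. Any reading of this position rests on a single number: the limit of > 48000 nM in this assay, at which 3 of the 4 values shown sit.

Still open, as far as these compounds go, is how ethyl, isopropyl or an amine on this carbon would read. Also open, from the compounds shown here alone, is whether any group here gives a lower number than propyl in compound 2.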